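Piperazine nitrogen substituent scan in a dithiocarbamate series

A few compounds are considered here, and "the series" means these few. Any claim that something is new, unique, unknown or untested is made for them only; others in the source may bear on it.

Measured in a functional assay on A-375 cells (Homo sapiens) for antiproliferative activity, read by CCK-8 assay, with a stated time of 72 h, tested at 2 uM; a higher number here means a stronger effect of the compound at the concentration tested, a lower number a weaker effect:
compound 1 `Nc1ccccc1NC(=O)c1ccc(CSC(=S)N2CCN(c3ccc(F)cc3)CC2)cc1` gives 20.9%
compound 2 `CN1CCN(C(=S)SCc2ccc(C(=O)Nc3ccccc3N)cc2)CC1` gives 36.6%
compound 3 `Nc1ccccc1NC(=O)c1ccc(CSC(=S)N2CCN(c3ncccn3)CC2)cc1` gives 24%

Compound 3 stands second highest of the three numbers, close to compound 1 and clearly under compound 2. Compound 4 `Nc1ccccc1NC(=O)c1ccc(CSC(=S)N2CCN(c3ccccc3F)CC2)cc1` is not yet measured; it differs from compound 3 by 2-fluorophenyl in place of pyrimidin-2-yl on an amine nitrogen in a ring. Within the data shown here, the only step of the same kind, one aryl group replacing another on that nitrogen, is a number 3.1 percentage points higher from compound 1 to compound 3 (within the scatter). The steps of a number 15.7 percentage points higher from compound 1 to compound 2 (beyond the scatter) and a number 12.6 percentage points lower from compound 2 to compound 3 (beyond the scatter) involve methyl and do not bear on this change. No change beyond the scatter is therefore expected in this assay. Compound 4 is estimated at 23%, between 12% and 36%. The expected step is a number 1 percentage points lower from compound 3 to compound 4 (within the scatter).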

Compound 4, a percentage reported as inhibition, at one concentration (the size of the read-out at that concentration, not a potency): 18.7%
Compound 4: the middle estimate sits 4.3 percentage points above what was measured, and the stated range covers the measured number.
By their numbers in this assay, from the lowest: compounds 4, 1 and 3 (each within the scatter of the next); then compound 2.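

In this assay 2-fluorophenyl on the amine nitrogen in the ring reads alike with pyrimidin-2-yl (a number 5.3 percentage points lower from compound 3 to compound 4 (within the scatter)) and alike with 4-fluorophenyl (a number 2.2 percentage points lower from compound 1 to compound 4 (within the scatter)), so these three aryl groups are not told apart at this position. Methyl remains separate from the newly added aryl group (a number 17.9 percentage points lower from compound 2 to compound 4 (beyond the scatter)), and all three aryl compounds sit under compound 2. No measured evidence bears on the reason for this result. On these data alone, whether an ethyl group, a hydroxyethyl chain or a carboxylic acid on this nitrogen would read with compound 2 or with the aryl compounds remains open.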